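Thiosemicarbazone series: bromo in place of trifluoromethyl

The source may report more compounds than this note shows. Statements on the series, on what has been measured and on what is new or still open speak of the compounds shown alone.

Compound 1 `FC(F)(F)c1ccccc1NC(=S)N/N=C/c1ccc2ccccc2n1` stands lowest of the two measured compounds in a functional assay on HT-29 cells (Homo sapiens) for antiproliferative activity, read by sulforhodamine B assay, with a stated time of 72 h (a higher number here means a weaker inhibitor, a lower number a stronger inhibitor), giving 18100 nM. Compound 2 `NC(=S)N/N=C/c1cc2ccccc2s1` gives 99200 nM in this assay, a gap to compound 1 that lies beyond the scatter. Compound 3 `S=C(N/N=C/c1ccc2ccccc2n1)Nc1ccccc1Br` has not been measured; it differs from compound 1 by bromo in place of trifluoromethyl on an aromatic carbon. Among the compounds with values here, no measured pair shows such a change, so the step is expected to be small, with no clear direction beyond the scatter. Compound 3 is therefore estimated at 16000 nM, within a range of 5000 nM to 50000 nM, which means an expected step of a 1.1-fold lower number from compound 1 to compound 3 (0.05 log units; within the scatter).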

Compound 3, half-maximal inhibitory concentration: > 100000 nM
Compound 3: no number, only a limit; the forecaster's own chance of this, stated with the estimate: 5%; middle value at least 6.2-fold (0.79 log units) away from the limit.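

Within the data shown here, this is the first step between compounds that differ in one place, and it shows that this position does not tolerate every swap: in this assay bromo in place of trifluoromethyl gives an at least 5.5-fold higher number from compound 1 to compound 3 (0.74 log units; beyond the scatter). The reading for compound 3 is a limit of the assay, not a number: the limit of > 100000 nM in this assay, at which 1 of the 3 values shown sits.

The compounds shown leave open how far the loss extends, and whether it belongs to bromo alone. Going by these compounds, how an amine, a methoxy group or plain hydrogen would read on this aromatic carbon also stays open.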